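This account rests on a few compounds, and the source may have more. Where it says the series, first, only, none or still open, it means among the compounds named here.

Compound 1 `COc1ccc(C(Nc2ccccc2)n2c(=O)ccc3cc(O)ccc32)cc1` gives 53700 nM in a functional assay on HCT-116 cells (Homo sapiens) for inhibition, read by MTT assay; a higher number here means a weaker inhibitor, a lower number a stronger inhibitor.
Compound 2 `COc1ccc(C(Nc2ccc([N+](=O)[O-])cc2)n2c(=O)ccc3cc(O)ccc32)cc1` gives 36600 nM in this assay.

Within the data shown here, compound 2 has the lower of the two numbers, yet the only measured step, a 1.5-fold lower number from compound 1 to compound 2 (0.17 log units; within the scatter), lies within the scatter, so the two compounds are not separated. Compound 3 `COc1ccc(C(Nc2ccc(Cl)cc2)n2c(=O)ccc3cc(O)ccc32)cc1` is still to be measured. It differs from compound 2 as follows: chloro in place of nitro on an aromatic carbon. Among the measured compounds shown here, the only step that bears on this position, the one from compound 1 to compound 2, stayed within the scatter, so no step beyond the scatter is expected in this assay: a 1.1-fold higher number from compound 2 to compound 3 (0.04 log units; within the scatter). Compound 3 is therefore estimated at 40000 nM, in the range 15000 nM to 100000 nM.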

Compound 3, half-maximal inhibitory concentration: 20400 nM
Compound 3: the middle estimate sits 2.0-fold (0.29 log units) above what was measured, and the stated range covers the measured number.
By their numbers in this assay, from the lowest: compounds 3, 2 and 1 (each within the scatter of the next, the first and the last beyond it).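

With chloro on the six-membered aromatic ring, para to a large group, this position gives its first step beyond the scatter in this assay, with a 2.6-fold lower number from compound 1 to compound 3 (0.42 log units; beyond the scatter). Replacing nitro with chloro, however, gives a 1.8-fold lower number from compound 2 to compound 3 (0.25 log units; within the scatter), so these two substituents are not separated. Nothing available accounts for the effect of chloro here.

The compounds shown leave open whether this position tolerates an amine or a carboxylic acid, and whether any group there would give more than a modest step.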